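Swapping the aryl group on the shared core: a flat series

This account rests on a few compounds, and the source may have more. Where it says the series, first, only, none or still open, it means among the compounds named here.

Compound 3 `CC(C)(C)Cc1c(-c2c(F)cccc2F)sc(N)c1C(=O)c1ccc(Cl)cc1` stands level with its two neighbours. In an assay on CHO cells for displacement of a labelled ligand from adenosine receptor A1 (Homo sapiens), read by scintillation counting, tested at 10 uM (on this read-out higher numbers stand for more inhibition at the one concentration tested (going by the name of the read-out) and lower numbers for less inhibition), compound 3 gives 1%; compound 1 `CC(C)(C)Cc1c(-c2ccncc2)sc(N)c1C(=O)c1ccc(Cl)cc1` gives 1%, and compound 2 `CC(C)(C)Cc1c(-c2ccc(F)cc2F)sc(N)c1C(=O)c1ccc(Cl)cc1` gives 1%. The three steps that join them, no change at the digits printed from compound 1 to compound 2 (within the scatter), no change at the digits printed from compound 1 to compound 3 (within the scatter) and no change at the digits printed from compound 2 to compound 3 (within the scatter), all fall within the scatter. Compound 4 `CC(C)(C)Cc1c(-c2ccc(Cl)cc2)sc(N)c1C(=O)c1ccc(Cl)cc1` differs from compound 3 by 4-chlorophenyl in place of 2,6-difluorophenyl on an aromatic carbon. Within the data shown here, because no change at the digits printed from compound 2 to compound 3 (within the scatter) left this assay unmoved, as did every other aryl exchange at this position so far, the expected step of a number 1 percentage points higher from compound 3 to compound 4 (within the scatter) is none beyond the scatter. Compound 4 is therefore estimated to give 2% in this assay, with a range of -8% to 12%.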

Compound 4, a percentage reported as inhibition, at one concentration (the size of the read-out at that concentration, not a potency): 1%
Compound 4: middle estimate off by 1 percentage points, on the high side, within the range that was stated.
By their numbers in this assay, from the lowest: compounds 1, 2, 3 and 4 (each within the scatter of the next).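

Moving to 4-chlorophenyl on the carbon next to the ring sulfur, the first group there to carry chlorine, gives no change at the digits printed from compound 3 to compound 4 (within the scatter) and no change at the digits printed from compound 2 to compound 4 (within the scatter) and also no change at the digits printed from compound 1 to compound 4 (within the scatter) in this assay as well. The four aryl groups on this carbon therefore cannot be told apart on this read-out, whether they carry fluorine, chlorine or a ring nitrogen. No supporting evidence bears on this result.

On these data alone, it remains open whether a non-aryl group at this carbon, such as an amine or a carboxylic acid, would move the reading. The same applies to a longer chain in place of the neopentyl group.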